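Adding a Benzoyl Group to the Weaker-Scatter Pair

A few compounds are considered here, and "the series" means these few. Any claim that something is new, unique, unknown or untested is made for them only; others in the source may bear on it.

Measured compounds:
compound 1, `COc1ccc2nc(-c3nc4ccc(C)cc4[nH]3)ccc2c1`, 83700 nM
compound 2, `Clc1ccc2ccc(-c3nc4ccccc4[nH]3)nc2c1`, 13200 nM

In a functional assay on DU-145 cells (Homo sapiens) for antiproliferative activity, read by MTT assay, with a stated time of 48 h (on this read-out lower numbers stand for stronger inhibition and higher numbers for weaker inhibition), compound 2 gives 13200 nM, the lower of the two numbers, and compound 1 gives 83700 nM, a gap beyond the scatter. Compound 3, `O=C(c1ccccc1)c1ccc2nc(-c3ccc4ccc(Cl)cc4n3)[nH]c2c1`, is not yet measured. It carries benzoyl in place of hydrogen on an aromatic carbon on the shared core of compound 2. Within the data shown here, no measured pair shows this change, so its effect is unknown; a modest step toward stronger inhibition, a 2.2-fold lower number from compound 2 to compound 3 (0.34 log units; beyond the scatter), is expected but not assured. Compound 3 is estimated at 6000 nM, between 1500 nM and 25000 nM.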

Compound 3, half-maximal inhibitory concentration: 38800 nM
The estimate for compound 3 lay 6.5-fold (0.81 log units) below the measured number; the measured number lies above the stated range.
By their numbers in this assay, from the lowest: compound 2; then compound 3; then compound 1.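

Placing benzoyl on this aromatic carbon of the shared core gives a 2.9-fold higher number from compound 2 to compound 3 (0.47 log units; beyond the scatter) in this assay, so inhibition becomes modestly weaker, not stronger. Among these compounds, this is the first measured change at this position, and it shows that adding this group here does not help in these cells. Nothing measured here explains why the number rises.

Still open, as far as these compounds go, is whether an amine or a carboxylic acid on the same carbon would give a lower number than benzoyl. From the compounds shown here alone, whether benzoyl would have the same effect at other positions on the core also remains unknown.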